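Methoxy for Cyano on the Benzylamine Arm

The source may report more compounds than this note shows. Statements on the series, on what has been measured and on what is new or still open speak of the compounds shown alone.

Of the compounds shown here, two of a shared core have been measured in a functional assay on CHO cells for agonist activity at Free fatty acid receptor 1 (Homo sapiens), read by reporter gene assay; on this read-out lower numbers stand for smaller maximal responses and higher numbers for larger maximal responses. Compound 1 `CN(C)Cc1ccc(CNc2ccc(CCC(=O)O)cc2)cc1` gives 12% in this assay, and compound 2 `N#Cc1ccc(CNc2ccc(CCC(=O)O)cc2)cc1` gives 49%, which is the higher of the two numbers. Among the compounds with values here, the single measured step, a number 37 percentage points higher from compound 1 to compound 2 (beyond the scatter), shows that what sits on the aromatic carbon of the outer ring matters strongly in this assay.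

Compound 3 `COc1ccc(CNc2ccc(CCC(=O)O)cc2)cc1` follows from compound 2 by methoxy in place of cyano on an aromatic carbon. Within the data shown here, no measured step involves a methoxy, so the step from compound 1 to compound 2 bears on it only by showing how wide the span at this position can be. A methoxy resembles neither of the two groups already tested, so the outcome is open. The author expects compound 3 to land somewhat below compound 2, the estimated step being a number 11 percentage points lower from compound 2 to compound 3 (beyond the scatter). Compound 3 is estimated at 38%, within a range from 15% to 65%.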

Compound 3, largest response reached (reported as percent of maximum), in percent of the reference or control that the assay uses: 159%
Estimate against measurement, compound 3: 121 percentage points below; the whole stated range lies below it.
By their numbers in this assay, from the lowest: compound 1; then compound 2; then compound 3.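

In this assay, the change a number 110 percentage points higher from compound 2 to compound 3 (beyond the scatter) shows that this aromatic carbon, para to a large group, can do far more than the first pair suggested, even though cyano and methoxy match in heavy-atom and hydrogen-bond-acceptor counts. The replacement of (dimethylamino)methyl, read a number 147 percentage points higher from compound 1 to compound 3 (beyond the scatter), widens the span at this position further and makes compound 3 the highest of the three, with a response well beyond the reference level. Nothing available explains why methoxy gives so much larger a response than either earlier group.

The compounds shown leave open whether this high response is particular to methoxy or would also arise with ethoxy, hydroxyl or methyl on the same carbon. They also leave open how much of each compound is needed, as this read-out gives only the largest response reached.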